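Chloro in place of methyl on the pendant phenyl ring

This account rests on a few compounds, and the source may have more. Where it says the series, first, only, none or still open, it means among the compounds named here.

Measured compounds:
Compound 1, `O=C(CNC(=O)c1ccc(F)cc1)NC(c1ccccc1)c1ccc(Cl)cc1`: 88 nM; 88 nM (2 entries)
Compound 2, `O=C(CNC(=O)c1ccc(F)cc1)NC(c1ccccc1)c1ccccc1`: 110 nM
Compound 3, `Cc1cccc(C(NC(=O)CNC(=O)c2ccc(F)cc2)c2ccccc2)c1`: 56 nM

Three compounds share one core and differ only in the substituent on one phenyl ring. In an assay for inhibition of sodium- and chloride-dependent glycine transporter 1 (Homo sapiens) (a higher number here means that more compound is needed for the effect, a lower number that less compound is needed), compound 3 gives 56 nM. Compound 2, which carries no substituent there, gives 110 nM. Compound 1, with a chloro group on that ring, gives 88 nM; 88 nM (2 entries). All three values lie close together; none of the gaps between them is larger than the usual scatter, so compound 3 stands among its neighbours rather than apart from them.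

Compound 4, `O=C(CNC(=O)c1ccc(F)cc1)NC(c1ccccc1)c1cccc(Cl)c1`, carries chloro in place of methyl on an aromatic carbon. Going by the values given here, the one directly comparable step, a 2.0-fold lower number from compound 2 to compound 3 (0.29 log units; within the scatter), shows that adding the methyl group changed little. Compound 1 and compound 2 show that a chloro group elsewhere on the same ring also leaves the number in the same neighbourhood. No measured change on this ring has moved the number beyond the scatter. The expected outcome is therefore a 1.3-fold higher number from compound 3 to compound 4 (0.10 log units; within the scatter), no shift beyond the scatter. Compound 4 is estimated at 70 nM, with a range from 35 nM to 140 nM.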

Compound 4, half-maximal effective concentration: 33 nM
The estimate for compound 4 lay 2.1-fold (0.33 log units) above the measured number, outside the stated range (below it).
By their numbers in this assay, from the lowest: compounds 4, 3 and 2 (each within the scatter of the next, the first and the last beyond it).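

In this assay, exchanging 3-methylphenyl for 3-chlorophenyl gives a 1.7-fold lower number from compound 3 to compound 4 (0.23 log units; within the scatter), so methyl and chloro cannot be told apart at this position. Measured against the plain phenyl ring, however, chloro at this position gives a 3.3-fold lower number from compound 2 to compound 4 (0.52 log units; beyond the scatter), the only step among these compounds that clears the scatter, though only modestly. Methyl at the same position gives a 2.0-fold lower number from compound 2 to compound 3 (0.29 log units; within the scatter), so the two groups can sit within the scatter of each other while only chloro separates clearly from hydrogen.

No supporting measurement is available to explain this difference. Still open, going by these compounds, is how other groups at this position would compare, such as fluoro, methoxy or an amine, and whether a chloro group here would give a similar step on a core with a different amide portion.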